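This account rests on a few compounds, and the source may have more. Where it says the series, first, only, none or still open, it means among the compounds named here.

In an ADME assay on SH-SY5Y cells (Homo sapiens) for cytotoxicity, read by MTT assay, with a stated time of 72 h (on this read-out lower numbers stand for stronger inhibition and higher numbers for weaker inhibition), compound 1 `COc1ccc(C(=O)N2CCN(CC(=O)N3CCN(CCCc4c[nH]c5ccc(F)cc45)CC3)CC2)cc1` gives 161000 nM, and compound 2 `COc1ccc(C(=O)N2CCN(CC(=O)N3CCN(CCCc4c[nH]c5ccc(OC)cc45)CC3)CC2)cc1` gives 190000 nM. Within the data shown here, compound 2 therefore stands within the scatter of the only other measured compound. Among the measured compounds shown here, the single measured step, a 1.2-fold higher number from compound 1 to compound 2 (0.07 log units; within the scatter), places methoxy in place of fluoro on an aromatic carbon. Compound 3 `COc1ccc2[nH]cc(CCCN3CCN(C(=O)CN4CCN(C(=O)c5cccc(Br)c5)CC4)CC3)c2c1` differs from compound 2 at another place: 3-bromophenyl in place of 4-methoxyphenyl on a carbonyl carbon. In words, this is 3-bromophenyl in place of 4-methoxyphenyl on a carbonyl carbon. For the measured compounds named here, no measured step covers a change at that carbonyl carbon, so the step from fluoro to methoxy bears on it only indirectly, as the one small step available. No step beyond the scatter is therefore expected in this assay. The expected change is a 1.3-fold lower number from compound 2 to compound 3 (0.10 log units; within the scatter). Compound 3 is estimated at 150000 nM, with an expected range from 65000 nM to 300000 nM.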

Compound 3, half-maximal inhibitory concentration: 105000 nM
Compound 3: the middle estimate sits 1.4-fold (0.15 log units) above what was measured; the range from low to high includes it.
By their numbers in this assay, from the lowest: compounds 3, 1 and 2 (each within the scatter of the next).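

In this assay, placing 3-bromophenyl in place of 4-methoxyphenyl on a carbonyl carbon gives a 1.8-fold lower number from compound 2 to compound 3 (0.26 log units; within the scatter), so the read-out does not separate these two compounds. The earlier compounds shown here covered only the exchange of fluoro for methoxy on an aromatic carbon, whereas this step shows that the substituted phenyl group on the carbonyl carbon can also be exchanged without a step beyond the scatter. Nothing available explains this result.

All three compounds carry a substituted phenyl ring on that carbonyl carbon, so the compounds shown leave open whether a cyclohexyl or a methyl group there would also stay within the scatter. They also leave open whether an amine or a carboxylic acid on the phenyl ring would give a step beyond it.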